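The source may hold more compounds than are shown below. What is called first, only, known or untested is meant among the compounds shown, and "the series" means these compounds.

Among the measured compounds shown here, compound 2 `CCCCN(c1nc2c(CO)cccc2o1)[C@H](C)c1ccc(-c2ccccc2-c2nnn[nH]2)cc1` holds the lower of the two numbers so far on an ADME assay on the whole organism (Macaca fascicularis) for pharmacokinetics, read by LC-MS, using cassette dosing, at a dose of 1 mg/kg by the oral route (on this read-out higher numbers stand for higher exposure at the dose given and lower numbers for lower exposure), at 20 ng.h/mL; compound 1 `CCCCN(c1nc2c(C(=O)O)cccc2o1)[C@H](C)c1ccc(-c2ccccc2-c2nnn[nH]2)cc1` gives 429 ng.h/mL. For the measured compounds named here, the only measured step, a 21-fold lower number from compound 1 to compound 2 (1.33 log units; beyond the scatter), shows that a single change at this aromatic carbon can move exposure widely. Compound 3 `CCCCN(c1nc2c(-c3ccccn3)cccc2o1)[C@H](C)c1ccc(-c2ccccc2-c2nnn[nH]2)cc1` carries pyridin-2-yl in place of hydroxymethyl on an aromatic carbon. Going by the values given here, no measured step involves pyridin-2-yl, so direction is open, and only the size of the known step warns that a large move is possible. Compound 3 is expected near 40 ng.h/mL, within 5 ng.h/mL to 300 ng.h/mL. The expected step of a 2.0-fold higher number from compound 2 to compound 3 (0.30 log units; within the scatter) is therefore modest against a wide band.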

Compound 3, area under the concentration-time curve: 248 ng.h/mL
Compound 3: the middle estimate sits 6.2-fold (0.79 log units) below what was measured, and the stated range covers the measured number.
By their numbers in this assay, from the lowest: compound 2; then compounds 3 and 1 (each within the scatter of the next).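

In this assay, an uncharged aromatic ring on this aromatic carbon gives a large gain over hydroxymethyl, with a 12-fold higher number from compound 2 to compound 3 (1.09 log units; beyond the scatter) in this change. With a 1.7-fold lower number from compound 1 to compound 3 (0.24 log units; within the scatter) in the swap from carboxy, a carboxy group is not required for exposure at this level, which the first step alone could not show. No evidence on hand accounts for either step.

Still open, from the compounds shown here alone, is whether the ring nitrogen of pyridin-2-yl matters, which a phenyl ring at this carbon would test. Going by these compounds, how a primary amide or an amine would read here also remains unknown.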